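The source may report more compounds than this note shows. Statements on the series, on what has been measured and on what is new or still open speak of the compounds shown alone.

Measured so far:
- compound 1 `O=S(=O)(c1cccc(F)c1)c1ccc2c(c1)CCC[C@H]2CN1CCCS1(=O)=O`: 31.6 nM
- compound 2 `NC(=O)CNC[C@@H]1CCCc2cc(S(=O)(=O)c3cccc(F)c3)ccc21`: 0.1 nM
- compound 3 `NC(=O)NC[C@@H]1CCCc2cc(S(=O)(=O)c3cccc(F)c3)ccc21`: 0.2 nM

In an assay on isolated protein for displacement of a labelled ligand from 5-hydroxytryptamine receptor 6 (Homo sapiens) (on this read-out lower numbers stand for stronger inhibition and higher numbers for weaker inhibition), compound 3 gives 0.2 nM, the second highest of the three numbers. Its nearest neighbour is compound 2, with a 2.0-fold higher number from compound 2 to compound 3 (0.30 log units; within the scatter), a gap that does not separate the two. Compound 1 stands far off, with a 160-fold lower number from compound 1 to compound 3 (2.20 log units; beyond the scatter) and a 320-fold lower number from compound 1 to compound 2 (2.50 log units; beyond the scatter), so the two open-chain groups bearing a nitrogen-hydrogen donor sit together at the low end and the cyclic group of compound 1 alone at the high end.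

Compound 4 `CC(C)(O)C(=O)NC[C@@H]1CCCc2cc(S(=O)(=O)c3cccc(F)c3)ccc21` is the next step from compound 3: 1-hydroxy-1-methylethyl in place of amino on a carbonyl carbon. The amide-type nitrogen and its hydrogen remain; only the far side of the carbonyl changes. The step from compound 2 to compound 3 shows that rearranging this end costs nothing beyond the scatter, whereas the step from compound 1 to compound 3 shows what the loss of the acyclic donor-bearing chain does. Compound 4 keeps that chain, so the expected step is small, a 3.0-fold higher number from compound 3 to compound 4 (0.48 log units; beyond the scatter), leaning toward a somewhat higher number. Compound 4 is therefore estimated at 0.6 nM, within 0.15 nM to 3 nM.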

Compound 4, inhibition constant: 2 nM
The estimate for compound 4 lay 3.3-fold (0.52 log units) below the measured number; low and high end bracket the measured number.
By their numbers in this assay, from the lowest: compounds 2 and 3 (each within the scatter of the next); then compound 4; then compound 1.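

In this assay, the far side of the carbonyl proves not to be indifferent: 1-hydroxy-1-methylethyl in place of amino on a carbonyl carbon gives a step beyond the scatter (a 10-fold higher number from compound 3 to compound 4 (1.00 log units; beyond the scatter)), whereas the earlier change between compounds with an open chain did not (a 2.0-fold higher number from compound 2 to compound 3 (0.30 log units; within the scatter)). (1-Hydroxy-1-methylethyl)carbonyl in place of carbamoylmethyl on the amine nitrogen gives a large step (a 20-fold higher number from compound 2 to compound 4 (1.30 log units; beyond the scatter)), yet compound 4 still keeps a large part of the advantage over the cyclic group (a 16-fold lower number from compound 1 to compound 4 (1.20 log units; beyond the scatter)). Nothing at hand bears on what lies behind these steps.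

The compounds shown leave open whether the step goes with the hydroxyl or with the branched carbons of the 1-hydroxy-1-methylethyl group. A tert-butyl or a hydroxymethyl on the same carbonyl carbon would separate the two.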